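Ethyl for methyl on the piperazine of a quinazoline series

The source may report more compounds than this note shows. Statements on the series, on what has been measured and on what is new or still open speak of the compounds shown alone.

Compound 1 `COc1cc2c(Nc3ccc(C#N)cc3)ncnc2cc1OCCCN1CCN(C)CC1` gives 48800 nM in a functional assay on A549 cells (Homo sapiens) for antiproliferative activity, read by MTT assay, with a stated time of 72 h; on this read-out lower numbers stand for stronger inhibition and higher numbers for weaker inhibition. Compound 2 `CCN1CCN(CCCOc2cc3ncnc(Nc4ccc(C#N)cc4)c3cc2OC)CC1` carries one change, (methyl in place of hydrogen on a saturated chain carbon bound to an amine nitrogen in a ring), and in this assay compound 2 gives 16000 nM, a step of a 3.1-fold lower number from compound 1 to compound 2 (0.48 log units; beyond the scatter). Compound 3 `COc1cc2c(Nc3cccc(C#N)c3)ncnc2cc1OCCCN1CCN(C)CC1` differs from compound 1 in its core by 3-cyanophenyl in place of 4-cyanophenyl on a nitrogen on an aromatic ring; in this assay compound 3 gives 27700 nM, and the step of a 1.8-fold lower number from compound 1 to compound 3 (0.25 log units; within the scatter) is within the scatter of the method. Compound 4 `CCN1CCN(CCCOc2cc3ncnc(Nc4cccc(C#N)c4)c3cc2OC)CC1` is not yet measured; it differs from compound 3 by methyl in place of hydrogen on a saturated chain carbon bound to an amine nitrogen in a ring, the same change as that from compound 1 to compound 2, at the same place. A step of about the same size is expected, so compound 4 is estimated to show a 2.8-fold lower number from compound 3 to compound 4 (0.44 log units; beyond the scatter) relative to compound 3, because that earlier change gave a 3.1-fold lower number from compound 1 to compound 2 (0.48 log units; beyond the scatter). Compound 4 is therefore expected to give about 10000 nM, between 4000 nM and 25000 nM.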

Compound 4, half-maximal inhibitory concentration: 18700 nM
Compound 4: the middle estimate sits 1.9-fold (0.27 log units) below what was measured, and the stated range covers the measured number.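

On the second core, the change from methyl to ethyl gives a 1.5-fold lower number from compound 3 to compound 4 (0.17 log units; within the scatter), and its two readings do not differ beyond the scatter: the same change on two cores in this assay, a 3.1-fold lower number (0.48 log units; beyond the scatter) from compound 1 to compound 2 and a 1.5-fold lower number (0.17 log units; within the scatter) from compound 3 to compound 4, 2.1-fold (0.31 log units) apart, within the scatter of two such steps. The change to 3-cyanophenyl in place of 4-cyanophenyl, read on the 4-ethylpiperazin-1-yl compounds, gives a 1.2-fold higher number from compound 2 to compound 4 (0.07 log units; within the scatter), and it too matches its earlier reading within the scatter: the same change on two cores in this assay, a 1.8-fold lower number (0.25 log units; within the scatter) from compound 1 to compound 3 and a 1.2-fold higher number (0.07 log units; within the scatter) from compound 2 to compound 4, 2.1-fold (0.31 log units) apart, within the scatter of two such steps. Neither change is seen to depend on the core in these four compounds, but two pairs do not show that either step has a fixed size or that it holds beyond them.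

The compounds shown leave open whether a propyl group in place of ethyl on the piperazine would lower the number further. They also leave open how a chlorine in place of the nitrile on the phenyl ring would read.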